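A Methoxy Group Added to the Aryl Ring of Compound 2

The compounds below may be only part of what the source reports. "The series", "measured", "known", "first", "only" and "open" are said of these compounds alone.

compound 1, `O=C1C2CCCN2C(=O)N1CCN1CCN(c2ccc([N+](=O)[O-])cc2)CC1`: > 10000 nM
compound 2, `O=C1C2CCCCN2C(=O)N1CCCN1CCN(c2ccccc2)CC1`: 11.4 nM

Going by the values given here, in an assay on isolated protein for binding affinity to Adrenergic receptor alpha-1 (Rattus norvegicus), read by radioligand binding (on this read-out lower numbers stand for stronger inhibition and higher numbers for weaker inhibition), compound 2 gives 11.4 nM, the only full number measured. Compound 1 reaches only (the limit of > 10000 nM in this assay, at which 1 of the 2 values shown sits), which is a limit of the assay and not a number. Compound 3, `COc1ccccc1N1CCN(CCCN2C(=O)C3CCCCN3C2=O)CC1`, differs from compound 2 by methoxy in place of hydrogen on an aromatic carbon, the same change read one bond further out as phenyl to 2-methoxyphenyl. Among the compounds with values here, no measured pair shows this change, so the size of its effect is open; a small shift toward stronger binding, within or just beyond the scatter, is expected. Compound 3 is therefore estimated at 6 nM, between 1.5 nM and 25 nM. The expected step is a 1.9-fold lower number from compound 2 to compound 3 (0.28 log units; within the scatter).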

Compound 3, inhibition constant: 9.9 nM
Compound 3: the middle estimate sits 1.7-fold (0.22 log units) below what was measured; the measured number falls inside the stated range.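

In this assay, going by these compounds alone, the first measured pair for methoxy in place of hydrogen on an aromatic carbon, ortho to a large group, gives a 1.2-fold lower number from compound 2 to compound 3 (0.06 log units; within the scatter). This place on the ring therefore accepts a methoxy group, and compound 3 binds within the scatter of compound 2. Nothing shown gives a reason for this result.

From the compounds shown here alone, whether a chlorine, a hydroxyl or an ethoxy group at this place would move the number beyond the scatter stays open. So does the effect of a methoxy group on another carbon of the ring.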